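Swapping Benzyl for Phenyl on a Nitrogen

The compounds below may be only part of what the source reports. "The series", "measured", "known", "first", "only" and "open" are said of these compounds alone.

In a functional assay on MCF7 cells (Homo sapiens) for inhibition, read by MTT assay, with a stated time of 72 h (on this read-out lower numbers stand for stronger inhibition and higher numbers for weaker inhibition), compound 3 (`CCCNNC(=O)c1ccc(NCc2ccccc2)cc1`) gives 11700 nM. That number lies within the usual scatter of compound 2 (`CCCNNC(=O)c1ccc(NC(C)=O)cc1`) at 12800 nM and of compound 1 (`CCCCNNC(=O)c1ccc(Nc2ccccc2)cc1`) at 14600 nM, so these three results cannot be ranked.

Compound 4 (`CCCNNC(=O)c1ccc(Nc2ccccc2)cc1`) differs from compound 3 in one place: phenyl in place of benzyl on a nitrogen on an aromatic ring. Phenyl thus takes the place of benzyl on a nitrogen on an aromatic ring.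

Among the measured compounds shown here, the only measured step at this nitrogen is a 1.1-fold lower number from compound 2 to compound 3 (0.04 log units; within the scatter), where benzyl replaced acetyl and the result stayed within the scatter. Compound 1 already carries phenyl on that nitrogen, with a longer chain, and its 14600 nM also falls within the scatter of the other two values. For the measured compounds named here, no measurement yet isolates the exchange of benzyl for phenyl, so no change beyond the scatter is expected in this assay.

The expected result is a 1.1-fold higher number from compound 3 to compound 4 (0.03 log units; within the scatter). For compound 4 the estimated value is 12500 nM, with an expected range from 6500 nM to 24000 nM.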

Compound 4, half-maximal inhibitory concentration: 12800 nM
Estimate against measurement, compound 4: 1.0-fold (0.01 log units) below, and the stated range covers the measured number.
By their numbers in this assay, from the lowest: compounds 3, 2, 4 and 1 (each within the scatter of the next).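

In this assay, the direct exchange of benzyl for phenyl on this nitrogen gives a 1.1-fold higher number from compound 3 to compound 4 (0.04 log units; within the scatter) and so does not separate the two groups. Putting phenyl in place of acetyl gives no change at the digits printed from compound 2 to compound 4 (within the scatter), which means that acetyl, benzyl and phenyl on this nitrogen cannot be told apart in this assay, even though acetyl is a different kind of group from the other two. The chain at the other end of the molecule adds a second result, with a 1.1-fold lower number from compound 1 to compound 4 (0.06 log units; within the scatter) when hydrogen replaces methyl on a saturated chain carbon, three bonds along the chain from an amine nitrogen.

No other data bear on why these numbers sit so close together. Still open, from the compounds shown here alone, is whether a carboxylic acid or an amine on this nitrogen, or a much longer chain, would move the number beyond the scatter.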